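The source may report more compounds than this note shows. Statements on the series, on what has been measured and on what is new or still open speak of the compounds shown alone.

Of the compounds shown here, three of a shared core have been measured in a functional assay on MGC-803 cells (Homo sapiens) for antiproliferative activity, read by MTT assay, with a stated time of 48 h; a lower number here means a stronger inhibitor, a higher number a weaker inhibitor. Compound 1 `COc1cc(OC)c2c(=O)c(OCCCOc3ccc(/C=C/C(=O)/C=C/c4scnc4C)cc3)c(-c3cc(OC)c(OC)c(OC)c3)oc2c1` gives 31700 nM. Compound 2 `COc1cc(OC)c2c(=O)c(OCCCCOc3ccc(/C=C/C(=O)/C=C/c4ccccn4)cc3)c(-c3cc(OC)c(OC)c(OC)c3)oc2c1` gives 1960 nM. Compound 3 `COc1cc(OC)c2c(=O)c(OCCCCOc3ccccc3/C=C/C(=O)/C=C/c3ccco3)c(-c3cc(OC)c(OC)c(OC)c3)oc2c1` gives 7900 nM, which places it second highest of the three numbers: the gap from compound 3 to compound 1 is beyond the scatter, and so is the gap from compound 3 to compound 2, which stands lowest.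

Compound 4 `COc1cc(OC)c2c(=O)c(OCCCCOc3ccccc3/C=C/C(=O)/C=C/c3cccs3)c(-c3cc(OC)c(OC)c(OC)c3)oc2c1` is the next compound in the series and has not yet been measured. It differs from compound 3 in one place only: thiophen-2-yl in place of furan-2-yl on a double-bonded chain carbon bound to a double-bonded chain carbon. Both groups are five-membered aromatic rings carrying a single hetero atom, with no change in hydrogen-bond donors or acceptors and no change in charge.

Within the data shown here, no pair of measured compounds differs by this change alone, so there is no measured step to lean on. Given how small the change is, the expectation is that the step from compound 3 to compound 4 in this assay will be a 1.3-fold lower number from compound 3 to compound 4 (0.12 log units; within the scatter), that is, not beyond the scatter, with at most a slight drift toward a lower number. On that basis compound 4 is estimated at 6000 nM, with a range from 2500 nM to 15000 nM.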

Compound 4, half-maximal inhibitory concentration: 20500 nM
Estimate against measurement, compound 4: 3.4-fold (0.53 log units) below; measured number above the stated range.
By their numbers in this assay, from the lowest: compound 2; then compound 3; then compounds 4 and 1 (each within the scatter of the next).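

In this assay, the change from furan-2-yl to thiophen-2-yl on a double-bonded chain carbon bound to a double-bonded chain carbon gives a 2.6-fold higher number from compound 3 to compound 4 (0.41 log units; beyond the scatter). Among these compounds, this position therefore responds to an exchange between two rings that match in heavy-atom count, ring size, hydrogen-bond donors and acceptors, and charge; the earlier compounds had no pair that isolated this position. Here the furan-2-yl ring gives the lower number, and the hetero atom is the only difference between the two rings, but nothing available accounts for the direction or size of this step.

The compounds shown leave open how a pyrrol-2-yl ring, with nitrogen as its hetero atom, or a plain phenyl ring would read at this same place. They also leave open whether the step keeps its direction elsewhere in the series, since neither compound 1 nor compound 2 has a partner that differs from it by this change alone.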